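Dropping a Methyl Group from the Most Lipophilic Compound

This account rests on a few compounds, and the source may have more. Where it says the series, first, only, none or still open, it means among the compounds named here.

So far three compounds have been measured in a physicochemical assay for lipophilicity, in phosphate buffer, measured as octanol-water partition, with a stated time of 24 h; a lower number here means a more polar compound, a higher number a more lipophilic compound:

compound 1, `S=C(N/N=C/c1ccc(Oc2ccccc2)cc1)Nc1ccc(Br)cc1`: 6.38
compound 2, `Cc1ccc(Oc2ccc(/C=N/NC(=S)Nc3ccc(Br)cc3)cc2)cc1`: 6.17
compound 3, `Cc1cc(Oc2ccc(/C=N/NC(=S)Nc3ccc(Br)cc3)cc2)ccc1Cl`: 7.89

Compound 3 stands highest of the three. Its nearest neighbour is compound 1, the step being a number 1.51 log units higher from compound 1 to compound 3 (beyond the scatter), and its furthest is compound 2, with a number 1.72 log units higher from compound 2 to compound 3 (beyond the scatter). Both of these steps are large, and both lie beyond the usual scatter.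

Compound 4, `S=C(N/N=C/c1ccc(Oc2ccc(Cl)cc2)cc1)Nc1ccc(Br)cc1`, has not yet been measured. It differs from compound 3 in one place: hydrogen in place of methyl on an aromatic carbon. The measured step that speaks most directly to this change is a number 0.21 log units lower from compound 1 to compound 2 (within the scatter), where a methyl group was added to an aromatic carbon and the number barely moved. The two large steps into compound 3 each bundle the methyl with the chloro group, so they do not separate the two. Taking the methyl away from compound 3 is therefore expected to leave this assay about where it is, with no step beyond the scatter. Compound 4 is expected to give about 7.7 in this assay, within a range from 6.9 to 8.4. The expected step of a number 0.19 log units lower from compound 3 to compound 4 (within the scatter) is estimated to fall within the scatter.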

Compound 4, partition coefficient: 6.24
Compound 4: the middle estimate sits 1.46 log units above what was measured, outside the stated range (below it).
By their numbers in this assay, from the lowest: compounds 2, 4 and 1 (each within the scatter of the next); then compound 3.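

In this assay, within the data shown here, the methyl group ortho to a chloro group turns out to carry the whole difference, with a number 1.65 log units lower from compound 3 to compound 4 (beyond the scatter) when it gives way to hydrogen, so a methyl at this place does not behave like the one in a number 0.21 log units lower from compound 1 to compound 2 (within the scatter), which sits elsewhere on the ring. The chloro group on its own shows no such effect, since the steps are a number 0.14 log units lower from compound 1 to compound 4 (within the scatter) and a number 0.07 log units higher from compound 2 to compound 4 (within the scatter). Among these compounds, then, only compound 3, with chloro and methyl on the same ring, stands apart, while compounds 1, 2 and 4 lie together whichever single group the ring carries, so the large steps into compound 3 cannot be credited to the chloro group alone.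

Among these compounds, nothing available here gives a reason for this jump, or shows whether it is a real feature of the pair or partly a quirk of the single high number for compound 3. Still open, going by these compounds, is whether an ethyl or a methoxy group in place of this methyl would give a number like that of compound 3, and whether the methyl would do so with no chloro group on the ring.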